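The compounds below may be only part of what the source reports. "The series", "measured", "known", "first", "only" and "open" are said of these compounds alone.

Working notes on the series.

Compound 1 `COc1cc(N2C(N)=C(C#N)C(/C=C/c3ccccc3)C3=C2CC(C)(C)CC3=O)cc(OC)c1OC` is the starting point. In a functional assay on Ehrlich cells (Mus musculus) for cytotoxicity (a lower number here means a stronger inhibitor, a higher number a weaker inhibitor), compound 1 is recorded as "not active" (no number reported), so no number stands against it and its standing on the numbers cannot be placed. Compound 2 `COc1cc(N2C(N)=C(C#N)C(c3cccc([N+](=O)[O-])c3)C3=C2CC(C)(C)CC3=O)cc(OC)c1OC` carries a 3-nitrophenyl group in the same place and in this assay compound 2 is likewise recorded as "not active" (no number reported). Among the measured compounds shown here, compound 3 `COc1ccccc1C1C(C#N)=C(N)N(c2cc(OC)c(OC)c(OC)c2)C2=C1C(=O)CC(C)(C)C2` carries a 2-methoxyphenyl group there and is the only member of the shared core with a number: in this assay compound 3 gives 26600 nM, a weak result.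

Compound 4 `COc1cc(N2C(N)=C(C#N)C(c3ccc(C)cc3)C3=C2CC(C)(C)CC3=O)cc(OC)c1OC` is not yet measured. Its change from compound 1 is 4-methylphenyl in place of 2-phenylethenyl on a saturated ring carbon. For the measured compounds named here, no step between measured compounds is available, so the size of the step in this assay is uncertain; the outcome for compound 4 is expected to stay in the weak range of compound 3 at 26600 nM or to come back without a number. The estimate for compound 4 in this assay is 40000 nM, with a range from 15000 nM to 150000 nM.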

Compound 4, half-maximal inhibitory concentration: 52900 nM
The estimate for compound 4 lay 1.3-fold (0.12 log units) below the measured number; measured number inside the range.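

The step on the saturated ring carbon, 4-methylphenyl in place of 2-methoxyphenyl, gives in this assay a 2.0-fold higher number from compound 3 to compound 4 (0.30 log units; within the scatter), so the two groups cannot be told apart at this position. Among the compounds shown here, compound 3 no longer stands alone as the only member of the shared core with a number, and the 4-methylphenyl group shows that a numerical read-out at this position is not confined to the 2-methoxyphenyl group; steps to compound 1 and compound 2 cannot be read, as neither has a number. Nothing on hand offers a reason for this result.

The compounds shown leave open what an amine or a carboxylic acid on this saturated ring carbon would give. Whether any group here can move the number beyond the scatter also remains unresolved.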